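The source may report more compounds than this note shows. Statements on the series, on what has been measured and on what is new or still open speak of the compounds shown alone.

Measured in an ADME assay on Vero 76 cells (Chlorocebus sabaeus) for cytotoxicity, read by MTT assay, with a stated time of 96 h; on this read-out higher numbers stand for lower toxicity in this test and lower numbers for higher toxicity in this test:

compound 1 `Brc1ccc(NCc2cn(-c3ccccc3)nc2-c2ccccc2)cc1` gives 52000 nM
compound 2 `Cc1ccc(NCc2cn(-c3ccccc3)nc2-c2ccc(C(F)(F)F)cc2)cc1` gives 82000 nM
compound 3 `Cc1ccc(NCc2cn(-c3ccccc3)nc2-c2ccccc2)cc1` gives > 100000 nM as a limit of the assay and not a number

Compound 1 gives 52000 nM and compound 2 gives 82000 nM, two numbers that lie within the scatter of each other. Compound 1 therefore stands level with compound 2 in this assay.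

Compound 4 `Cc1ccc(-c2nn(-c3ccccc3)cc2CNc2ccc(Br)cc2)cc1` departs from compound 1 at one place. The change is methyl in place of hydrogen on an aromatic carbon, so that phenyl becomes 4-methylphenyl. Within the data shown here, no measured step makes this exact swap, and the evidence that bears on it is indirect. Methyl in place of bromo gave an at least 1.9-fold higher number from compound 1 to compound 3 (0.28 log units; that floor lies within the scatter), while hydrogen in place of trifluoromethyl gave an at least 1.2-fold higher number from compound 2 to compound 3 (0.08 log units; that floor lies within the scatter). Both steps are floors set by a limit, and neither goes beyond the scatter. A step beyond the scatter is therefore not expected in this assay, and the measured steps point to no direction. The expected step is a 1.1-fold higher number from compound 1 to compound 4 (0.02 log units; within the scatter), which stays within the scatter. For compound 4 the estimated value is 55000 nM, with an expected range from 27000 nM to 100000 nM.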

Compound 4, half-maximal cytotoxic concentration: 92000 nM
Compound 4: the middle estimate sits 1.7-fold (0.22 log units) below what was measured; the range from low to high includes it.
By their numbers in this assay, from the lowest: compounds 1, 2 and 4 (each within the scatter of the next). At a limit, above all of these: compound 3.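

The change from phenyl to 4-methylphenyl gives, in this assay, a 1.8-fold higher number from compound 1 to compound 4 (0.25 log units; within the scatter), so methyl on this aromatic carbon, para to a large group, produces no change that can be told from the scatter. The earlier step at this same place, hydrogen in place of trifluoromethyl, ended at a limit and could be read only as a floor, whereas this step runs between two numbers and its size can be read in full. Among these compounds, it therefore gives the first complete reading of a change at this place, though it holds only with the bromo of compound 1 kept in place.

The compounds shown leave open whether a different group at this place, such as an amine, a carboxylic acid or a longer chain, would move the number beyond the scatter in either direction. They also leave open how far any change toward lower toxicity in this test could be sized, since the read-out has an upper end that one compound already reaches: the limit of > 100000 nM in this assay, at which 1 of the 4 values shown sits.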